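This account rests on a few compounds, and the source may have more. Where it says the series, first, only, none or still open, it means among the compounds named here.

In an assay on microsomes from liver for inhibition of sterol O-acyltransferase 1 (Rattus norvegicus) (on this read-out higher numbers stand for weaker inhibition and lower numbers for stronger inhibition), three compounds have been tested so far. Compound 1 `CCCCCCCCCCC(C)(C)NC(=O)c1c(OC)cc(OC)cc1OC` reached only the limit of the assay, giving > 10000 nM. Compound 2 `CCCCCCCCCCCCn1nnc(C(NC(=O)c2ccc(Cl)cc2)c2ccccc2)n1` gives 440 nM. Compound 3 `CCCCCCCCCCCCn1nnnc1C(NC(=O)c1c(C)cccc1C)c1ccccc1` gives 180 nM, the lower of the two numbers, and its gap to compound 2 lies beyond the usual scatter. Compound 4 `CCCCCCCCCCCCn1nnnc1C(NC(=O)c1ccnc(SC)c1)c1ccccc1` has not yet been measured. It differs from compound 3 in one place: a group of 8 heavy atoms (6 carbon, 1 nitrogen, 1 sulfur; one six-membered aromatic ring with 1 hetero atom) in place of a group of 8 heavy atoms (8 carbon; one six-membered aromatic ring of carbon only), on a carbonyl carbon. Among the measured compounds shown here, no measured pair mirrors this change, so the direction rests on expectation alone. For compound 4 a modest shift toward weaker inhibition is expected, a step of a 2.8-fold higher number from compound 3 to compound 4 (0.44 log units; beyond the scatter). Compound 4 is therefore estimated at 500 nM, with a likely range from 150 nM to 2000 nM.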

Compound 4, half-maximal inhibitory concentration: 140 nM
Beside the measured number, compound 4's estimate is 3.6-fold (0.55 log units) above it, and the stated range ends above it.
By their numbers in this assay, from the lowest: compounds 4 and 3 (each within the scatter of the next); then compound 2. At a limit, above all of these: compound 1.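

In this assay the swap of 2,6-dimethylphenyl for a six-membered aromatic ring holding a nitrogen and a sulfur, on the carbonyl carbon, gives a 1.3-fold lower number from compound 3 to compound 4 (0.11 log units; within the scatter) and so leaves inhibition level. This place therefore tolerates a ring with hydrogen-bond acceptors as well as a ring of carbon only, at least for this one pair. Nothing measured here accounts for that match.

Still open, as far as these compounds go, is whether a plain phenyl, or a ring bearing an amine or a carboxylic acid, would hold inhibition on this carbonyl carbon equally well.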